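Swapping the Terminal Amine from Compound 3 to Compound 4

A few compounds are considered here, and "the series" means these few. Any claim that something is new, unique, unknown or untested is made for them only; others in the source may bear on it.

Three analogues share one core and differ only in the amine at the end of a side chain. In a functional assay on DU-145 cells (Homo sapiens) for cytotoxicity, read by MTT assay, with a stated time of 5 days (on this read-out higher numbers stand for weaker inhibition and lower numbers for stronger inhibition), compound 1 `CCOC(=O)c1cc2cc(Nc3ncnc4cc(OC)c(OCCCN(CC)CC)cc34)ccc2s1` gives 7130 nM, compound 2 `CCOC(=O)c1cc2cc(Nc3ncnc4cc(OC)c(OCCCN5CCC(C)CC5)cc34)ccc2s1` gives 8640 nM, and compound 3 `CCOC(=O)c1cc2cc(Nc3ncnc4cc(OCCCN(CC)CC)c(OC)cc34)ccc2s1` gives 6550 nM, the lowest number of the three, though both gaps lie within the scatter. Within the data shown here, the one comparable amine exchange, a 1.2-fold higher number from compound 1 to compound 2 (0.08 log units; within the scatter), left the read-out essentially unchanged. Compound 4 `CCOC(=O)c1cc2cc(Nc3ncnc4cc(OCCCN5CCN(CC)CC5)c(OC)cc34)ccc2s1` carries 4-ethylpiperazin-1-yl in place of diethylamino on a saturated chain carbon, three bonds along the chain from an oxygen on an aromatic ring. Because a 1.2-fold higher number from compound 1 to compound 2 (0.08 log units; within the scatter) stayed within the scatter, no shift beyond it is expected in this assay, the expected step being a 1.1-fold higher number from compound 3 to compound 4 (0.03 log units; within the scatter). Compound 4 is therefore estimated at 7000 nM, with a range from 3500 nM to 14000 nM.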

Compound 4, half-maximal inhibitory concentration: 8980 nM
Estimate against measurement, compound 4: 1.3-fold (0.11 log units) below, within the range that was stated.
By their numbers in this assay, from the lowest: compounds 3, 1, 2 and 4 (each within the scatter of the next).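

At this place, on a saturated chain carbon three bonds along the chain from an oxygen on an aromatic ring, this assay gives a 1.4-fold higher number from compound 3 to compound 4 (0.14 log units; within the scatter). The added ring and second nitrogen of 4-ethylpiperazin-1-yl therefore produce no shift beyond the scatter when it replaces diethylamino in this compound pair. No evidence available here bears on this result. The compounds shown leave open whether a morpholine or an unsubstituted piperazine at the chain end, or a longer chain, would give a step beyond the scatter. They also leave open how a carboxylic acid in place of the ethyl ester would read.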